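A few compounds are considered here, and "the series" means these few. Any claim that something is new, unique, unknown or untested is made for them only; others in the source may bear on it.

Of the compounds shown here, three sharing one core have been tested in a functional assay on the whole organism (stomach) for inhibition, with Rattus norvegicus as the target, at a dose of 100 mg/kg by the intraduodenal route; a lower number here means less inhibition, a higher number more inhibition at the dose given (going by the name of the read-out). Compound 1 `N=C(S)CCn1nc(-c2cccs2)ccc1=O` gives 50.2%. Compound 2 `Cc1cc(-c2ccccc2)nn(CCC(=N)S)c1=O` gives 60.2%, the largest of the three numbers, though compound 1 lies within the usual scatter of it. Compound 3 `Cc1ccc(=O)n(CCCCC(=N)S)n1` gives 29.5%, a number that falls beyond the scatter below compound 2. Compound 4 `N=C(S)CCn1nc(-c2ccccc2)ccc1=O` has not yet been measured in this assay. Set against compound 2 it differs in one place: hydrogen in place of methyl on an aromatic carbon. Within the data shown here, no measured pair shows this change, so its effect can only be estimated. A modest step is expected, downward or none beyond the scatter, a number 8.2 percentage points lower from compound 2 to compound 4 (within the scatter). Compound 4 is therefore expected to give about 52%, within a range from 32% to 72%.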

Compound 4, a percentage reported as inhibition, in the whole organism at one dose (the size of the read-out at that dose, not a potency): 53.7%
Estimate against measurement, compound 4: 1.7 percentage points below; the measured number falls inside the stated range.
By their numbers in this assay, from the lowest: compound 3; then compounds 1, 4 and 2 (each within the scatter of the next).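

In this assay, hydrogen in place of methyl on the aromatic carbon opposite the ring nitrogen gives a number 6.5 percentage points lower from compound 2 to compound 4 (within the scatter) and so this methyl has no effect that can be told from the scatter. Phenyl in place of thiophen-2-yl gives a number 3.5 percentage points higher from compound 1 to compound 4 (within the scatter) and so these two groups cannot be told apart at this dose either. Nothing measured here explains these results. As far as these compounds go, whether a larger group on that carbon, such as an amine or a carboxylic acid, would move the number beyond the scatter stays open. So does the effect of a pyridine ring in place of phenyl.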